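The compounds below may be only part of what the source reports. "The series", "measured", "known", "first", "only" and "open" are said of these compounds alone.

In an ADME assay on L02 cells (Homo sapiens) for cytotoxicity, read by MTT assay, with a stated time of 24 h (on this read-out lower numbers stand for stronger inhibition and higher numbers for weaker inhibition), compound 1 (`COc1cc(/C=C/c2ccc(OCc3ccc(C(F)(F)F)cc3)cc2)cc(OC)c1`) gives > 100000 nM as a limit of the assay, not a number. Compound 2 (`COc1cc(/C=C/c2ccc(OCC(=O)NCc3ccccc3)cc2)cc(OC)c1`) gives > 100000 nM as a limit too. Among the compounds with values here, the only measured step, a step that the two limits leave unreadable from compound 1 to compound 2 in these notes, puts benzylcarbamoyl in place of 4-(trifluoromethyl)phenyl and has no readable size. The series therefore rests on the limit of > 100000 nM in this assay, at which 2 of the 2 values shown sit, and offers no numeric value to scale from.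

Compound 3 (`COCCCOc1ccc(/C=C/c2cc(OC)cc(OC)c2)cc1`) is not yet measured. Its difference from compound 1 is 2-methoxyethyl in place of 4-(trifluoromethyl)phenyl on a saturated chain carbon bound to an oxygen on an aromatic ring in the same place as the measured step, with 2-methoxyethyl in place of 4-(trifluoromethyl)phenyl on a saturated chain carbon bound to an oxygen on an aromatic ring.

Two different groups at this place both end at the limit of > 100000 nM in this assay, at which 2 of the 2 values shown sit, in this assay and neither gives a number, so compound 3 is expected to sit there as well. The estimate for the change is a step that the limit leaves unreadable from compound 1 to compound 3 and is expected to stay within the scatter, with no direction. The expected value for compound 3 is 150000 nM within an estimated range of 60000 nM to 400000 nM and is most likely reported as a limit again.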

Compound 3, half-maximal inhibitory concentration: > 100000 nM
Compound 3 ended at the assay's limit; the forecaster's own chance of this, stated with the estimate: 85%; the middle value is on the limit's open side.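

In this assay no new step can be read from compound 3, since its steps to compound 1 and compound 2 join only limits of the assay, not numbers: the limit of > 100000 nM in this assay, at which 3 of the 3 values shown sit.

The compounds shown leave open whether any group on a saturated chain carbon bound to an oxygen on an aromatic ring gives a numeric value in this assay at all.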